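The compounds below may be only part of what the source reports. "The series", "measured", "known", "first", "only" and "open" are said of these compounds alone.

Values measured in a functional assay on KB cells (Homo sapiens) for inhibition, read by sulforhodamine B assay, with a stated time of 72 h (on this read-out lower numbers stand for stronger inhibition of growth and higher numbers for weaker inhibition of growth), are these:

- Compound 1 `C=C1CC[C@@H]2[C@](C)(COC(=O)c3cccnc3)[C@H](OC(=O)c3cccnc3)CC[C@@]2(C)[C@@H]1/C=C/C1=CCOC1=O` gives > 30000 nM as a limit of the assay
- Compound 2 `C=C1CC[C@@H]2[C@](C)(COC(=O)CCCCC3CCSS3)[C@H](OC(=O)CCCCC3CCSS3)CC[C@@]2(C)[C@@H]1/C=C/C1=CCOC1=O` gives 11700 nM
- Compound 3 `C=C1CC[C@@H]2[C@](C)(COC(=O)C3CCCN3C(=O)OC(C)(C)C)[C@H](O)CC[C@@]2(C)[C@@H]1/C=C/C1=CCOC1=O` gives 20100 nM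

Compound 3 (20100 nM) and compound 2 (11700 nM) lie within the usual scatter of each other, so this assay does not separate them. Compound 1 gives only a limit (> 30000 nM) and not a number.

Compound 4 `C=C1CC[C@@H]2[C@](C)(COC(=O)CCCCC3CCSS3)[C@H](O)CC[C@@]2(C)[C@@H]1/C=C/C1=CCOC1=O` has not yet been measured. It differs from compound 3 by one change on a carbonyl carbon: 1-(tert-butoxycarbonyl)pyrrolidin-2-yl leaves and a group with no common name enters (a group of 9 heavy atoms (7 carbon, 2 sulfur; one five-membered non-aromatic ring with 2 hetero atoms) in place of a group of 12 heavy atoms (9 carbon, 1 nitrogen, 2 oxygen; one five-membered non-aromatic ring with 1 hetero atom), on a carbonyl carbon). Within the data shown here, no two measured compounds differ in only one place, so no direct step is available as a guide. The entering group is also present in compound 2 (11700 nM) and the leaving group in compound 3 (20100 nM). Those two values lie within the scatter of each other, although the two compounds differ elsewhere as well. No shift beyond the scatter is therefore expected in this assay, and the estimated 1.5-fold lower number from compound 3 to compound 4 (0.19 log units; within the scatter) is small, in the direction of a slightly lower number. The estimate for compound 4 is 13000 nM, with an expected range from 5500 nM to 29000 nM in this measurement.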

Compound 4, concentration for 50% growth inhibition: > 30000 nM
Compound 4: only a limit was reported (the forecaster's own chance of this, stated with the estimate: 15%); middle value at least 2.3-fold (0.36 log units) from the limit.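

Compound 4 is reported only as a limit of the assay in this assay, not as a number. Among these compounds, replacing the group of 11 heavy atoms on the oxygen on a saturated carbon with a hydrogen atom gives an at least 2.5-fold higher number from compound 2 to compound 4 (0.40 log units; beyond the scatter), the first single-place comparison to show that the ester at this oxygen matters. On the carbonyl carbon, exchanging 1-(tert-butoxycarbonyl)pyrrolidin-2-yl for the sulfur-containing group gives an at least 1.4-fold higher number from compound 3 to compound 4 (0.17 log units; that floor lies within the scatter), so the sulfur-containing group brings no gain over the group it replaces, although no real loss can be claimed from this floor alone. The true size of both steps cannot be read, because they end at a cut-off rather than a measured value: the limit of > 30000 nM in this assay, at which 2 of the 4 values shown sit.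

The compounds shown leave open whether the ester on the oxygen on a saturated carbon must carry this sulfur-containing group, or whether a small acetyl group or a longer chain ending in an amine would serve as well. They also leave open what a carboxylic acid at the end of the chain on the carbonyl carbon would do to growth inhibition.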